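Swapping chloro for trifluoromethyl on the aryl ring

The source may report more compounds than this note shows. Statements on the series, on what has been measured and on what is new or still open speak of the compounds shown alone.

This series shares a core in which a substituted pyrrole carries a phenyl-type ring, an aminomethyl side chain and a hydrazine link to a chloroquinoline; the question followed here is how such changes affect the survival of a leukaemia cell line. Going by the values given here, in an ADME assay on K562 cells (Homo sapiens) for cytotoxicity, read by MTT assay, with a stated time of 72 h (on this read-out higher numbers stand for lower toxicity in this test and lower numbers for higher toxicity in this test), compound 1 `CCN(CC)Cc1cc(-c2ccccc2)n(Nc2ccnc3cc(Cl)ccc23)c1C` gives 3620 nM, the only number in the set so far. Compound 2 `CCN(CC)Cc1cc(-c2ccc(Cl)cc2)n(Nc2ccnc3cc(Cl)ccc23)c1C` carries a chloro group on the phenyl-type ring; in this assay compound 2 has the entry "not determined" (no result reported), so no number exists for it. Compound 3 `Cc1c(CN2CCCC2)cc(-c2ccc(Cl)cc2)n1Nc1ccnc2cc(Cl)ccc12` keeps that chloro group and changes the aminomethyl side chain to a pyrrolidine; in this assay compound 3 likewise has the entry "not determined" (no result reported), so its standing rests on nothing more than the value of compound 1 for the whole series.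

Compound 4 `Cc1c(CN2CCCC2)cc(-c2ccc(C(F)(F)F)cc2)n1Nc1ccnc2cc(Cl)ccc12` differs from compound 3 in one place: trifluoromethyl in place of chloro on an aromatic carbon. Among the compounds with values here, with no measured step between compound 3 and compound 4 in this assay, and only compound 1 as an anchor, the expectation is a result in the same region as compound 1, with no change that could be distinguished from the scatter. For compound 4 the estimate in this assay is 3000 nM, within a range of 1000 nM to 10000 nM.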

Compound 4, half-maximal cytotoxic concentration: 1220 nM
The estimate for compound 4 lay 2.5-fold (0.39 log units) above the measured number, and the stated range covers the measured number.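

Going by these compounds alone, compound 3 has no single number in this assay, so the value of compound 4, 1220 nM, has no partner and no step from compound 3 to compound 4 can be read. The compounds shown leave open whether trifluoromethyl in place of chloro shifts cytotoxicity at all. No supporting data bear on the value of compound 4.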